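Shortening the Long Chain of Compound 1

This account rests on a few compounds, and the source may have more. Where it says the series, first, only, none or still open, it means among the compounds named here.

Compound 1 `CCCCCCCCCCCCCCCCOP(=O)(O)OCCSC(=S)N1CCCCCC1`: > 100000 nM (a limit)
Compound 2 `CCCCCCCCCCOP(=O)(O)OCCSC(=S)N1CCN(C)CC1`: 29000 nM
Compound 3 `CCCCCCCCOP(=O)(O)OCCSC(=S)N1CCCCCC1`: not yet measured

Compound 1 has only a limit and no number in a functional assay on MDA-MB-231 cells (Homo sapiens) for inhibition, read by MTT assay, with stated times of 18 h and 4 h; on this read-out lower numbers stand for stronger inhibition and higher numbers for weaker inhibition (the limit of > 100000 nM in this assay, at which 1 of the 2 values shown sits). Compound 3 keeps the core of compound 1, with hydrogen in place of octyl on a saturated chain carbon, eight bonds along the chain from an oxygen on an unsaturated carbon. Among the compounds with values here, the only number so far belongs to compound 2 (29000 nM), which carries a decyl chain and a different ring. On that basis, a moderate expected step toward lower numbers in this assay seems likely (an at least 2.5-fold lower number from compound 1 to compound 3 (0.39 log units; beyond the scatter)), though another limit remains possible. Compound 3 is estimated at 40000 nM (range 10000 nM to 100000 nM).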

Compound 3, half-maximal inhibitory concentration: 27000 nM
Compound 3: middle estimate off by 1.5-fold (0.17 log units), on the high side, within the range that was stated.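

Hydrogen in place of octyl on a saturated chain carbon, eight bonds along the chain from an oxygen on an unsaturated carbon, gives the core of compound 1 a measured number in this assay, with an at least 3.7-fold lower number from compound 1 to compound 3 (0.56 log units; beyond the scatter). This shows that the chain length at this position matters in this assay, with the shorter chain giving the lower number. The true size of the step stays unknown because compound 1 has only a limit: the limit of > 100000 nM in this assay, at which 1 of the 3 values shown sits.

The compounds shown leave open whether the number would keep falling with a shorter chain such as butyl. They also leave open what an amine or a carboxylic acid on this chain would do.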